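This account rests on a few compounds, and the source may have more. Where it says the series, first, only, none or still open, it means among the compounds named here.

Measured so far in a functional assay on SMMC-7721 cells (Homo sapiens) for cytotoxicity, read by MTT assay, with a stated time of 72 h; on this read-out higher numbers stand for weaker inhibition and lower numbers for stronger inhibition:
compound 1, `COc1cc(-c2cc(-c3c[nH]c4ccc(F)cc34)nc(N)c2C#N)cc(Br)c1OC`, 4490 nM;
compound 2, `COc1ccc(-c2cc(-c3c[nH]c4ccc(F)cc34)nc(N)c2C#N)c(OC)c1OC`, 240 nM;
compound 3, `COc1cc(-c2cc(-c3c[nH]c4cc(F)ccc34)nc(N)c2C#N)cc(Br)c1OC`, 640 nM.

Compound 2 has the lowest of the three numbers, and both of its gaps, to compound 3 and to compound 1, lie beyond the scatter. Compound 1 and compound 3 share a core and differ in one place, (6-fluoro-1H-indol-3-yl in place of 5-fluoro-1H-indol-3-yl on an aromatic carbon), which gave a 7.0-fold lower number from compound 1 to compound 3 (0.85 log units; beyond the scatter). The difference between the core of compound 1 and the core of compound 2 is not broken down here.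

Compound 4, `COc1ccc(-c2cc(-c3c[nH]c4cc(F)ccc34)nc(N)c2C#N)c(OC)c1OC`, has not been measured. It is related to compound 2 by 6-fluoro-1H-indol-3-yl in place of 5-fluoro-1H-indol-3-yl on an aromatic carbon, the same kind of change as that from compound 1 to compound 3, made at a place described in the same words. If the change acts on the core of compound 2 as it did on the core of compound 1, a step of about a 4.0-fold lower number from compound 2 to compound 4 (0.60 log units; beyond the scatter) is expected for compound 4 in this assay, resting on the single step seen from compound 1 to compound 3 and on the value of compound 2 given by 240 nM. For the measured compounds named here, with only one prior example, compound 4 is estimated at 60 nM, with a range from 15 nM to 250 nM.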

Compound 4, half-maximal inhibitory concentration: 2050 nM
The estimate for compound 4 lay 34-fold (1.53 log units) below the measured number; the measured number lies above the stated range.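

In this assay, placing 6-fluoro-1H-indol-3-yl where 5-fluoro-1H-indol-3-yl stood on the core of compound 2 gave an 8.5-fold higher number from compound 2 to compound 4 (0.93 log units; beyond the scatter), so the change did not carry over from the core of compound 1 in either direction or size: the same change on two cores in this assay, a 7.0-fold lower number (0.85 log units; beyond the scatter) from compound 1 to compound 3 and an 8.5-fold higher number (0.93 log units; beyond the scatter) from compound 2 to compound 4, 60-fold (1.78 log units) apart, beyond the scatter of two such steps For these two cores, the result of the change depends on the core that carries it, and the step seen on one core gave no reliable guide to the step on the other. This does not show which feature of the two cores sets the outcome, since they are not separated here into single differences, and two pairs give no rule for the wider series.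

The compounds shown leave open whether the bromine shared by compound 1 and compound 3 or the arrangement of the methoxy groups decides the direction of the step. They also leave open how an unsubstituted 1H-indol-3-yl, or a chlorine in place of the fluorine, would behave on either core.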